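A Fluoro-to-Chloro Swap on Compound 3

The compounds below may be only part of what the source reports. "The series", "measured", "known", "first", "only" and "open" are said of these compounds alone.

In a functional assay on A549 cells (Homo sapiens) for antiproliferative activity, read by MTT assay, with a stated time of 48 h (on this read-out lower numbers stand for stronger inhibition and higher numbers for weaker inhibition), compound 1 `COc1ccc2[nH]c(-c3cn(-c4ccccc4)nc3-c3ccc(F)cc3)nc2c1` gives 1960 nM and compound 2 `Cc1ccc2[nH]c(-c3cn(-c4ccccc4)nc3-c3ccc(F)cc3)nc2c1` gives 1440 nM while compound 3 `O=C(OCc1ccccc1)c1ccc2[nH]c(-c3cn(-c4ccccc4)nc3-c3ccc(F)cc3)nc2c1` gives 21500 nM as the highest of the three numbers. The change to compound 4 `O=C(OCc1ccccc1)c1ccc2[nH]c(-c3cn(-c4ccccc4)nc3-c3ccc(Cl)cc3)nc2c1` is chloro in place of fluoro on an aromatic carbon. Among the compounds with values here, no measured step touches this group. The step of a 1.4-fold lower number from compound 1 to compound 2 (0.13 log units; within the scatter) stays small, while the large steps of an 11-fold higher number from compound 1 to compound 3 (1.04 log units; beyond the scatter) and a 15-fold higher number from compound 2 to compound 3 (1.17 log units; beyond the scatter) concern benzyloxycarbonyl instead. With no direct evidence, no shift beyond the scatter is expected in this assay here. The expected step is a 1.2-fold lower number from compound 3 to compound 4 (0.08 log units; within the scatter) and carries no firm direction. For compound 4 the estimate is 18000 nM within an expected range of 7000 nM to 45000 nM for now.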

Compound 4, half-maximal inhibitory concentration: 7730 nM
Estimate against measurement, compound 4: 2.3-fold (0.37 log units) above; the measured number falls inside the stated range.
By their numbers in this assay, from the lowest: compounds 2 and 1 (each within the scatter of the next); then compound 4; then compound 3.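

Replacing the 4-fluorophenyl with a 4-chlorophenyl gives a 2.8-fold lower number from compound 3 to compound 4 (0.44 log units; beyond the scatter) in this assay. Within the data shown here, this shows that a position no earlier step touched still responds to the exchange of a single atom, with a modest step in this benzyloxycarbonyl series. Nothing available explains this shift. From the compounds shown here alone, whether the same swap would have a similar effect with the methoxy of compound 1 or the methyl of compound 2 in place of the benzyloxycarbonyl stays open. So does the outcome of placing a bromine or an amine at this position.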